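This account rests on a few compounds, and the source may have more. Where it says the series, first, only, none or still open, it means among the compounds named here.

Measured so far:
- compound 1 `CCCC(CCO)n1cnc2c(Cl)ncnc21`; in a functional assay on HCT-116 cells (Homo sapiens) for antiproliferative activity, read by MTT assay, with a stated time of 48 h (on this read-out higher numbers stand for weaker inhibition and lower numbers for stronger inhibition), compound 1 gives > 50000 nM, a limit of the assay
- compound 2 `CCCCCCCCCCC(CCO)n1cnc2c(Cl)ncnc21`; in this assay compound 2 gives 4930 nM

Compound 1 stands at the limit of the assay, the weaker end of the two values shown (the limit of > 50000 nM in this assay, at which 1 of the 2 values shown sits). Going by the values given here, the one measured step is an at least 10-fold lower number from compound 1 to compound 2 (1.00 log units; beyond the scatter), so lengthening the chain on the core of compound 1 moves the number down out of the limit.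

Compound 3 `OCCC(CO)n1cnc2c(Cl)ncnc21` differs from compound 1 as follows: hydroxy in place of ethyl on a saturated chain carbon, two bonds along the chain from an aromatic nitrogen. This change goes the other way from the measured step, shortening the chain and bringing in a polar group, so no lower number is expected; compound 3 is expected to remain at the limit as compound 1 does. For compound 3 the estimate in this assay is 80000 nM, with a range from 30000 nM to 300000 nM. The expected step is a step that the limit leaves unreadable from compound 1 to compound 3, which means no change beyond the scatter.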

Compound 3, half-maximal inhibitory concentration: > 50000 nM
Compound 3 ended at the assay's limit; the forecaster's own chance of this, stated with the estimate: 85%; the middle value does not contradict the limit.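

Compound 1 and compound 3 both sit at a limit of this assay, so no step between them can be read: the limit of > 50000 nM in this assay, at which 2 of the 3 values shown sit.

The compounds shown leave open whether hydroxy in place of ethyl changes the number in this assay at all, and what it would do on the longer chain of compound 2.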